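From Benzyl to Cyclohexyl: An Expected Cytotoxicity Step

A few compounds are considered here, and "the series" means these few. Any claim that something is new, unique, unknown or untested is made for them only; others in the source may bear on it.

compound 1 `O=C(NCc1ccccc1)N(Cc1ccccn1)n1cnnc1` — 31000 nM
compound 2 `CCc1ccc(NC(=O)N(Cc2ccc(OC)c(OC)c2)n2cnnc2)cc1` — 22900 nM

Of the compounds shown here, two have so far been tested in a functional assay on B16-F10 cells (Mus musculus) for cytotoxicity, read by MTT assay, with a stated time of 48 h; a lower number here means a stronger inhibitor, a higher number a weaker inhibitor. In this assay compound 1 gives 31000 nM, and compound 2 gives 22900 nM; these two numbers lie within the usual scatter of one another, so neither compound can be called the stronger of the pair, and compound 1 simply sits alongside compound 2.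

Among the compounds with values here, no single-change step between measured compounds is available here. Compound 3 `O=C(NC1CCCCC1)N(Cc1ccccn1)n1cnnc1` differs from compound 1 in one place only: cyclohexyl in place of benzyl on an amide-type nitrogen. Within the data shown here, nothing among the measured compounds speaks to this particular change, so the estimated step is a 1.0-fold lower number from compound 1 to compound 3 (0.01 log units; within the scatter), no larger than the scatter, in this assay. Compound 3 is therefore expected to give about 30000 nM in this assay, with a plausible range from 10000 nM to 90000 nM.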

Compound 3, half-maximal inhibitory concentration: 35800 nM
Estimate against measurement, compound 3: 1.2-fold (0.08 log units) below, and the stated range covers the measured number.
By their numbers in this assay, from the lowest: compounds 2, 1 and 3 (each within the scatter of the next).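

Within the data shown here, exchanging benzyl for cyclohexyl on the amide-type nitrogen gives, in this assay, a 1.2-fold higher number from compound 1 to compound 3 (0.06 log units; within the scatter) and so provides the first direct reading at this position. Within this pair, the six-membered aromatic ring of carbon gives way to a non-aromatic one with no difference that can be told apart from the scatter, although one pair cannot show how the position responds to other groups. Nothing available offers an explanation for this result.

As far as these compounds go, whether a longer open chain, such as n-hexyl, would read the same at this position remains open. So does whether a benzyl group carrying an amine or a carboxylic acid would move the number beyond the scatter, since the compounds shown place only benzyl and cyclohexyl here on the core of compound 1.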